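The source may report more compounds than this note shows. Statements on the series, on what has been measured and on what is new or still open speak of the compounds shown alone.

In a functional assay on CHO cells with adenosine receptor A1 (Homo sapiens) as the target, read by cAMP accumulation and immunoassay, with a stated time of 6 min, tested at 0.1 uM (a higher number here means a weaker effect of the compound at the concentration tested, a lower number a stronger effect), the measured compounds are:
compound 1 `Nc1scc(CN2CCN(c3ccc(Cl)cc3F)CC2)c1C(=O)c1ccc(Cl)cc1`, -9.4%;
compound 2 `Nc1scc(CN2CCN(c3cccc(C(F)(F)F)c3)CC2)c1C(=O)c1ccc(Cl)cc1`, -30%;
compound 3 `Nc1scc(CN2CCN(c3cccc(F)c3)CC2)c1C(=O)c1ccc(Cl)cc1`, -37%.

Compound 1 has the highest of the three numbers; compound 2 lies nearest to it and compound 3 furthest, both beyond the scatter. Compound 4 `Nc1scc(CN2CCN(CCCc3ccc(Cl)cc3)CC2)c1C(=O)c1ccc(Cl)cc1` has not yet been measured. It differs from compound 1 in one place: 3-(4-chlorophenyl)propyl in place of 4-chloro-2-fluorophenyl on an amine nitrogen in a ring. For the measured compounds named here, two measured steps bear on this, since both change the group on the same ring nitrogen: a number 20.6 percentage points lower from compound 1 to compound 2 (beyond the scatter) and a number 27.6 percentage points lower from compound 1 to compound 3 (beyond the scatter). Each lowered the number modestly, beyond the scatter. Those steps swapped one six-membered aromatic ring for another, whereas compound 4 gains a 3-(4-chlorophenyl)propyl, so the precedent is indirect. A modest downward step is nevertheless expected, a number 15.6 percentage points lower from compound 1 to compound 4 (beyond the scatter). Compound 4 is therefore estimated at -25%, within -45% to 0%.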

Compound 4, a percentage reported as activity, at one concentration (the size of the read-out at that concentration, not a potency): -3%
For compound 4 the middle estimate is 22 percentage points below the measured one; the range from low to high includes it.
By their numbers in this assay, from the lowest: compounds 3 and 2 (each within the scatter of the next); then compounds 1 and 4 (each within the scatter of the next).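

In this assay, replacing the directly attached aryl group on the ring nitrogen with 3-(4-chlorophenyl)propyl gives no readable change, a number 6.4 percentage points higher from compound 1 to compound 4 (within the scatter), so the earlier downward steps do not extend to this group. The same group instead separates clearly from the two meta-free... 

Correction, final text:

In this assay, replacing 4-chloro-2-fluorophenyl on the ring nitrogen with 3-(4-chlorophenyl)propyl gives no readable change, a number 6.4 percentage points higher from compound 1 to compound 4 (within the scatter), so the earlier downward steps do not extend to this group. The same group stands clearly apart from 3-fluorophenyl, a number 34 percentage points higher from compound 3 to compound 4 (beyond the scatter), and from 3-(trifluoromethyl)phenyl, a number 27 percentage points higher from compound 2 to compound 4 (beyond the scatter). Nothing at hand accounts for these differences. From the compounds shown here alone, it remains open whether a shorter 2-(4-chlorophenyl)ethyl chain, or a propyl chain ending in 3-fluorophenyl, would fall with compound 4 or with compound 3.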